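A few compounds are considered here, and "the series" means these few. Any claim that something is new, unique, unknown or untested is made for them only; others in the source may bear on it.

Measured in a functional assay on Jurkat cells (Homo sapiens) for inhibition, read by MTT assay, with a stated time of 72 h; on this read-out higher numbers stand for weaker inhibition and lower numbers for stronger inhibition:
- compound 1 `CO[C@@H]1[C@H]2OC(=O)C[C@H]2O[C@@H]1[C@H](O)c1ccccc1`: 24900 nM
- compound 2 `CO[C@@H]1[C@H]2OC(=O)C[C@H]2O[C@@H]1[C@@H](OC)c1ccccc1`: 1690 nM

Compound 2, at 1690 nM, has the lower number of the two and so the stronger inhibition, and its gap to compound 1 at 24900 nM lies beyond the scatter. Next in line is compound 3 `CO[C@@H]1[C@H]2OC(=O)C[C@H]2O[C@@H]1[C@H](OC)c1ccccc1`, not yet measured. Its relation to compound 2 is the two compounds have the same atoms and bonds and differ only in configuration as drawn: 1 of 5 stereo elements differ; a stereocentre at a saturated chain carbon is drawn S in compound 2 and R in compound 3. The stereocentre concerned is drawn S in compound 2 and R in compound 3. Within the data shown here, the series holds no measured pair that differs in configuration alone, so the size of this step in this assay is poorly constrained. A small rise in the number is expected, not clearly beyond the scatter, though a larger move either way remains possible. The expected change is a 1.5-fold higher number from compound 2 to compound 3 (0.17 log units; within the scatter). For compound 3 the estimated value is 2500 nM, with an expected range of 600 nM to 11000 nM.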

Compound 3, half-maximal inhibitory concentration: 2360 nM
The estimate for compound 3 lay 1.1-fold (0.03 log units) above the measured number; low and high end bracket the measured number.
By their numbers in this assay, from the lowest: compounds 2 and 3 (each within the scatter of the next); then compound 1.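

In this assay the series now holds its first pair that differs in configuration alone, and the step is a 1.4-fold higher number from compound 2 to compound 3 (0.15 log units; within the scatter), so at this saturated chain carbon the R and S drawings cannot be told apart on this read-out. The methyl change can also now be read as a single change, as an 11-fold lower number from compound 1 to compound 3 (1.02 log units; beyond the scatter), a large step that the earlier pair of compounds did not isolate. The comparison of compound 2 with compound 3 tests this one stereocentre and nothing else: the fact that compounds 2 and 3 differ only in the configuration as drawn

From the compounds shown here alone, it remains open whether configuration at this carbon matters as little when the oxygen carries hydrogen rather than methyl. The compounds shown also leave open how an ethyl ether, an acetate ester or an amine at this carbon would compare with the methyl ether.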